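One Group Swapped on a Sulfonamide Nitrogen

The source may hold more compounds than are shown below. What is called first, only, known or untested is meant among the compounds shown, and "the series" means these compounds.

Three compounds sharing one core have been measured in a functional assay on cells (leukaemia cell line, Homo sapiens) for inhibition, read by sulforhodamine B assay, with a stated time of 48 h (on this read-out lower numbers stand for stronger inhibition of growth and higher numbers for weaker inhibition of growth), with these results

Compound 1 `Cc1cc(NS(=O)(=O)c2ccc(-c3cnc(C4CC4)o3)cc2)ccc1Cl` gives 216 nM
Compound 2 `O=S(=O)(Nc1ccc(Br)c(Cl)c1)c1ccc(-c2cnc(C3CC3)o2)cc1` gives 491 nM
Compound 3 `O=S(=O)(Nc1ccc(F)cc1F)c1ccc(-c2cnc(C3CC3)o2)cc1` gives 356 nM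

Compound 3 cannot be told apart from either of the other two, as a 1.6-fold higher number from compound 1 to compound 3 (0.22 log units; within the scatter) and a 1.4-fold lower number from compound 2 to compound 3 (0.14 log units; within the scatter) show. Compound 3 with 356 nM therefore sits inside the scatter of both.

The unmeasured compound 4 `O=S(=O)(Nc1ccc(I)c(Cl)c1)c1ccc(-c2cnc(C3CC3)o2)cc1` keeps the same core but carries 3-chloro-4-iodophenyl in place of 2,4-difluorophenyl on a sulfonamide nitrogen.

The three measured swaps at this nitrogen are the best guide to this change. Two of them stayed within the scatter, as noted above. The largest, a 2.3-fold higher number from compound 1 to compound 2 (0.36 log units; beyond the scatter), was only modest. The closest measured group is the 4-bromo-3-chlorophenyl of compound 2, which gives 491 nM and so offers no sign of a large shift.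

No step beyond the scatter is therefore expected in this assay for this change. The estimated step is a 1.2-fold higher number from compound 3 to compound 4 (0.08 log units; within the scatter) and its direction is uncertain. For compound 4 the estimated value is 430 nM with an expected range of 190 nM to 950 nM on repeated measurement.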

Compound 4, concentration for 50% growth inhibition: 1010 nM
For compound 4 the middle estimate is 2.3-fold (0.37 log units) below the measured one; the measured number lies above the stated range.
By their numbers in this assay, from the lowest: compounds 1, 3 and 2 (each within the scatter of the next, the first and the last beyond it); then compound 4.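

In this assay, compound 4 is the first compound whose number stands beyond the scatter of every other compound shown, which makes it the weakest of the four (a 2.8-fold higher number from compound 3 to compound 4 (0.45 log units; beyond the scatter); a 4.7-fold higher number from compound 1 to compound 4 (0.67 log units; beyond the scatter)). The most telling comparison is the narrowest one, since iodo in place of bromo on an aromatic carbon is a single-atom change and still moves the number beyond the scatter (a 2.1-fold higher number from compound 2 to compound 4 (0.31 log units; beyond the scatter)), so this position responds to one halogen on the ring and not only to a swap of the whole aryl group, although each of these steps remains modest. Nothing here gives a measured property of these groups or any other explanation for the shift.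

As far as these compounds go, this single bromo-to-iodo pair cannot establish a trend among the halogens, so it remains open how a 3-chloro-4-fluorophenyl group would compare with compound 2 and compound 4. The compounds shown also carry only halogens and methyl on this ring, which leaves open what a methoxy group, an amine or a carboxylic acid would do at this sulfonamide nitrogen's aryl group.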